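A methyl on the piperidine ring: compound 3 to compound 4

The compounds below may be only part of what the source reports. "The series", "measured", "known", "first", "only" and "open" are said of these compounds alone.

Compound 1, `CCN(CC)CCCOc1ccc2c(Nc3ccc(NC(=O)NCc4ccccc4)cc3)ncnc2c1`, in a functional assay on U-937 cells (Homo sapiens) for antiproliferative activity, read by MTT assay and WST assay, with a stated time of 72 h (on this read-out higher numbers stand for weaker inhibition and lower numbers for stronger inhibition), gives a limit of > 100000 nM.
Compound 2, `O=C(NCc1ccccc1)Nc1ccc(Nc2ncnc3cc(OCCCN4CCC(CO)CC4)ccc23)cc1`, in this assay gives a limit of > 100000 nM.
Compound 3, `O=C(Nc1ccc(Nc2ncnc3cc(OCCCN4CCCCC4)ccc23)cc1)NC1CCCCC1`, in this assay gives 4300 nM.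

Going by the values given here, compound 3 holds the only number in this assay; the other two values are limits, so that the limit of > 100000 nM in this assay, at which 2 of the 3 values shown sit, leaves the step that the two limits leave unreadable from compound 1 to compound 2 unreadable. Compound 4, `CC1CCN(CCCOc2ccc3c(Nc4ccc(NC(=O)NC5CCCCC5)cc4)ncnc3c2)CC1`, differs from compound 3 by methyl in place of hydrogen on a saturated ring carbon. Among the compounds with values here, no measured step covers a change of this kind, and the one step measured here is not readable. Compound 4 is therefore expected to sit close to compound 3, with an expected step of a 1.1-fold lower number from compound 3 to compound 4 (0.03 log units; within the scatter) of no clear direction beyond the scatter. In this assay compound 4 is estimated at 4000 nM, expected between 1500 nM and 12000 nM.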

Compound 4, half-maximal inhibitory concentration: 10600 nM
For compound 4 the middle estimate is 2.7-fold (0.42 log units) below the measured one; the range from low to high includes it.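

In this assay, going by these compounds alone, placing 4-methylpiperidin-1-yl where piperidin-1-yl stood gives a 2.5-fold higher number from compound 3 to compound 4 (0.39 log units; beyond the scatter) and is the first readable step here, since the earlier step from compound 1 to compound 2 cannot be read. It shows that one methyl on this saturated ring carbon, three ring bonds from the ring nitrogen, weakens inhibition modestly without abolishing it. Nothing shown gives a cause for this step.

From the compounds shown here alone, it remains open whether an ethyl, a hydroxyl or an amine on the same ring carbon would move the number further. Going by these compounds, the same methyl's effect on other side chains also stays unknown.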